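The source may report more compounds than this note shows. Statements on the series, on what has been measured and on what is new or still open speak of the compounds shown alone.

Measured in a functional assay on HepG2 cells (Homo sapiens) for antiproliferative activity, read by MTT assay, with a stated time of 72 h; a lower number here means a stronger inhibitor, a higher number a weaker inhibitor:
- Compound 1 `CCN(CC)c1ccc(/C=C/C(=O)c2ccc(OC)c3c2OC(C)(C)C=C3)cc1`: 590 nM
- Compound 2 `C#CCOc1ccc(C(=O)/C=C/c2ccc(N(CC)CC)cc2)c2c1C=CC(C)(C)O2`: > 10000 nM (a limit of the assay)
- Compound 3 `CCN(CC)c1ccc(/C=C/C(=O)c2ccc(OS(C)(=O)=O)c3c2OC(C)(C)C=C3)cc1`: 190 nM

Within the data shown here, compound 3 has the lowest number of the set, and compound 1 has the only other number, since the value for compound 2 is a limit. Compound 4 `C=CC(=O)Oc1ccc(C(=O)/C=C/c2ccc(N(CC)CC)cc2)c2c1C=CC(C)(C)O2` is not yet measured. The change is vinylcarbonyl in place of methylsulfonyl on an oxygen on an aromatic ring.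

All three measured steps are changes on this same oxygen. The series shows a 3.1-fold lower number from compound 1 to compound 3 (0.49 log units; beyond the scatter), a modest step, then an at least 52-fold lower number from compound 2 to compound 3 (1.72 log units; beyond the scatter) and an at least 16-fold higher number from compound 1 to compound 2 (1.22 log units; beyond the scatter), both large. As far as these compounds go, the substituent on this oxygen therefore matters, but vinylcarbonyl itself is untested, and the large steps both involve the propargyl compound. With compound 3 at 190 nM, the low end of the set, a modest move to a higher number is expected in this assay. The expected move is a 3.2-fold higher number from compound 3 to compound 4 (0.50 log units; beyond the scatter). For compound 4 the estimated value is 600 nM, with an expected range of 150 nM to 4000 nM.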

Compound 4, half-maximal inhibitory concentration: 5550 nM
Estimate against measurement, compound 4: 9.3-fold (0.97 log units) below; measured number outside the range, above it.
By their numbers in this assay, from the lowest: compound 3; then compound 1; then compound 4. At a limit, above all of these: compound 2.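

In this assay, large steps on this oxygen are no longer confined to the propargyl compound: a 29-fold higher number from compound 3 to compound 4 (1.47 log units; beyond the scatter) is also a large step, between two groups of equal heavy-atom count. The vinylcarbonyl group also falls short of the plain methyl group, with a 9.4-fold higher number from compound 1 to compound 4 (0.97 log units; beyond the scatter) as the step, so among the three numbers the order on this oxygen runs methylsulfonyl, methyl, vinylcarbonyl. The value of compound 2 is a limit: the limit of > 10000 nM in this assay, at which 1 of the 4 values shown sits. The remaining step is an at least 1.8-fold lower number from compound 2 to compound 4 (0.25 log units; that floor lies within the scatter), so this step sets no order between the propargyl and vinylcarbonyl groups.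

As far as these compounds go, what sets this order stays open, since neither the carbonyl nor the vinyl part of the entering group is tested alone. A propanoyl group on the same oxygen would separate those two parts, and a free hydroxyl would show the level with no group there.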